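Methyl to methoxy on the aryl of compound 2

A few compounds are considered here, and "the series" means these few. Any claim that something is new, unique, unknown or untested is made for them only; others in the source may bear on it.

In a functional assay on MCF7 cells (Homo sapiens) for antiproliferative activity, read by MTT assay, with a stated time of 72 h (a lower number here means a stronger inhibitor, a higher number a weaker inhibitor), compound 1 `N#Cc1ccc(-c2csc(N3N=C(c4ccc(N5CCCCC5)cc4)CC3c3ccc(Cl)cc3)n2)cc1` gives 9760 nM. Compound 2 `Cc1ccc(-c2csc(N3N=C(c4ccc(N5CCCCC5)cc4)CC3c3ccc(Cl)cc3)n2)cc1` reaches only the limit of > 100000 nM in this assay, so no number is known for it. Among the measured compounds shown here, the only measured step is an at least 10-fold higher number from compound 1 to compound 2 (1.01 log units; beyond the scatter). Compound 3 `COc1ccc(-c2csc(N3N=C(c4ccc(N5CCCCC5)cc4)CC3c3ccc(Cl)cc3)n2)cc1` differs from compound 2 by methoxy in place of methyl on an aromatic carbon, 4-methylphenyl to 4-methoxyphenyl. For the measured compounds named here, no measured step covers methyl to methoxy, and compound 2 stands at a limit (the limit of > 100000 nM in this assay, at which 1 of the 2 values shown sits), so the expected step of an at least 2.0-fold lower number from compound 2 to compound 3 (0.30 log units; that floor lies within the scatter) is uncertain in size and direction. Compound 3 is estimated at 50000 nM, between 15000 nM and 150000 nM, with a real chance of another limit.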

Compound 3, half-maximal inhibitory concentration: > 100000 nM
Compound 3: no number, only a limit; the forecaster's own chance of this, stated with the estimate: 40%; middle value at least 2.0-fold (0.30 log units) away from the limit.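

Methoxy on this aryl carbon gives no more readable activity than methyl: compound 3, like compound 2, stands only at a limit, and no number is known for either. Replacing the nitrile with methoxy gives an at least 10-fold higher number from compound 1 to compound 3 (1.01 log units; beyond the scatter), so among these three compounds only the nitrile-bearing compound 1 gives a number. The step between the two limit compounds cannot be read: the limit of > 100000 nM in this assay, at which 2 of the 3 values shown sit.

Open, on these data alone, is whether the number for compound 1 is specific to the nitrile. A carboxylic acid, an amide or an amine on the same aromatic carbon could test this.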